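A few compounds are considered here, and "the series" means these few. Any claim that something is new, unique, unknown or untested is made for them only; others in the source may bear on it.

Compound 3 `CCCCNc1nc(N)nnc1OCc1ccccc1` gives 1930 nM in an assay on isolated protein for agonist activity at Toll-like receptor 8 (Homo sapiens) (a lower number here means that less compound is needed, a higher number that more compound is needed for the effect), which is the highest of the three numbers recorded so far. Its nearest neighbour is compound 2 `CCCCNc1nc(N)nnc1OCc1cccnc1`, which gives 590 nM in this assay, and the furthest is compound 1 `CCCCNc1nc(N)nnc1OC(C)C`, which gives 460 nM in this assay. Within the data shown here, the single step recorded between measured compounds that differ in one place is a 3.3-fold higher number from compound 2 to compound 3 (0.51 log units; beyond the scatter), so replacing a ring that carries a hydrogen-bond acceptor with a ring of carbon only went with a higher number.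

Compound 4 `CCCCNc1nc(N)nnc1OCCOC` has not yet been measured. It differs from compound 3 in one place: methoxymethyl in place of phenyl on a saturated chain carbon bound to an oxygen on an aromatic ring. Among the measured compounds shown here, no measured step introduces a methoxymethyl group, so the expectation rests on two observations. Compound 2 gives 590 nM, showing that a group with a hydrogen-bond acceptor in this place went with a lower number than the phenyl of compound 3, and compound 1 gives 460 nM, showing that a small group without a ring in this place went with the lowest number of the three. Compound 4 combines both features, so a lower number than compound 3 is expected, with a step of about a 3.2-fold lower number from compound 3 to compound 4 (0.51 log units; beyond the scatter). The estimate for compound 4 is therefore 600 nM, within a range of 250 nM to 1500 nM.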

Compound 4, half-maximal effective concentration: 1000 nM
For compound 4 the middle estimate is 1.7-fold (0.22 log units) below the measured one, within the range that was stated.
By their numbers in this assay, from the lowest: compounds 1, 2, 4 and 3 (each within the scatter of the next, the first and the last beyond it).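

In this assay, methoxymethyl in place of phenyl gives a 1.9-fold lower number from compound 3 to compound 4 (0.29 log units; within the scatter), and methoxymethyl in place of pyridin-3-yl gives a 1.7-fold higher number from compound 2 to compound 4 (0.23 log units; within the scatter), so this position tolerates the loss of the aromatic ring without a step that can be read beyond the scatter, although the step between the two ring-bearing compounds, a 3.3-fold higher number from compound 2 to compound 3 (0.51 log units; beyond the scatter), can be. The comparison with the small branched group reads differently: 2-methoxyethyl in place of isopropyl on an oxygen on an aromatic ring gives a 2.2-fold higher number from compound 1 to compound 4 (0.34 log units; beyond the scatter), a modest step, which shows that an open chain carrying a hydrogen-bond acceptor does not by that alone match the isopropyl of compound 1. Nothing in the data explains why these steps fall as they do.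

The compounds shown leave open whether the oxygen in the chain of compound 4 matters at all, which a plain butyl chain in the same place would test. They also leave open how a terminal amine or hydroxyl on this chain, or a longer ether chain, would compare with the isopropyl of compound 1.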